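The source may report more compounds than this note shows. Statements on the series, on what has been measured and on what is new or still open speak of the compounds shown alone.

Three compounds share a core that carries a three-carbon chain from an indole-type ring to a piperidine nitrogen, and all have been tested in an assay on CHO cells for displacement of a labelled ligand from 5-hydroxytryptamine receptor 1D (Homo sapiens); a lower number here means a stronger inhibitor, a higher number a weaker inhibitor. Compound 1 `CC(=O)Nc1ccc([C@H](C)NCC2CCN(CCCc3c[nH]c4ccc(-n5cnnc5)cc34)CC2)cc1` gives 0.6 nM in this assay. Compound 2 `CC(C)=CCCN(C)C1CCN(CCCc2c[nH]c3ccc(-n4cnnc4)cc23)CC1` gives 2.6 nM in this assay, the second highest of the three numbers; its nearest neighbour is compound 1, and the gap between the two lies beyond the scatter of repeated measurements. Compound 3 `CNS(=O)(=O)Cc1ccc2[nH]cc(CCCN3CCC(N[C@H](C)c4ccccc4)CC3)c2c1` gives 43 nM in this assay, the highest number of the set and the furthest from compound 2.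

The unmeasured compound 4 `CN(C1CCN(CCCc2c[nH]c3ccc(-n4cnnc4)cc23)CC1)S(=O)(=O)c1ccccc1` differs from compound 2 in one place: phenylsulfonyl in place of 4-methylpent-3-en-1-yl on an amine nitrogen. Among the compounds with values here, no measured pair in the set shows this exact change, so the expectation rests on compound 2 alone. The step from compound 2 to compound 4 is expected to go towards a higher number, a 5.8-fold higher number from compound 2 to compound 4 (0.76 log units; beyond the scatter). Compound 4 is therefore estimated to give about 15 nM in this assay, with a range from 3 nM to 80 nM.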

Compound 4, half-maximal inhibitory concentration: 1.5 nM
Compound 4: middle estimate off by 10-fold (1.00 log units), on the high side, and the stated range ends above it.
By their numbers in this assay, from the lowest: compound 1; then compounds 4 and 2 (each within the scatter of the next); then compound 3.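

In this assay, replacing the open carbon chain with phenylsulfonyl gives a 1.7-fold lower number from compound 2 to compound 4 (0.24 log units; within the scatter), so the two compounds cannot be told apart. This amine nitrogen therefore keeps its number within the scatter across a large change in the group it carries: the chain has no ring and no hydrogen-bond acceptors, while phenylsulfonyl brings a six-membered aromatic ring and two hydrogen-bond acceptors. No measurement offered here explains why such different groups give matching results.

The compounds shown leave open whether the sulfonyl link itself matters, which a benzoyl group on the same nitrogen would test. They also leave open whether a methylsulfonyl group, which has no phenyl ring, or a phenylsulfonyl group carrying a fluorine or methoxy substituent would give a similar number.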